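A few compounds are considered here, and "the series" means these few. Any claim that something is new, unique, unknown or untested is made for them only; others in the source may bear on it.

Compounds with numbers so far:

Compound 1 `CC(C)(C)c1ccc(C(=O)NCc2ccc(C(=O)O)cc2F)cc1`: 7.8 nM
Compound 2 `CC(C)(C)c1ccc(C(=O)NCc2ccc(NC(=O)C(F)(F)F)cc2Cl)cc1`: 14 nM
Compound 3 `COc1ccc(CNC(=O)c2ccc(C(C)(C)C)cc2)cc1`: 150 nM

All three were tested in an assay on HeLa cells with Bile acid receptor (Homo sapiens) as the target, read by a luciferase reporter, with a stated time of 24 h; on this read-out lower numbers stand for an effect already at smaller amounts and higher numbers for an effect only at larger amounts of compound. On this read-out compound 2 gives the second highest of the three numbers. Its nearest neighbour is compound 1, whose number is lower by a margin that falls within the usual scatter of repeated measurements, so the two cannot be told apart with confidence. Compound 3 stands furthest away, with a number higher by a margin well beyond the scatter, so compound 3 is clearly the one that needs the largest amount to act.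

Compound 4 `CC(C)(C)c1ccc(C(=O)NCc2ccc(C(=O)O)cc2Cl)cc1` has not yet been measured. Compared with compound 2, the change is carboxy in place of ((trifluoromethyl)carbonyl)amino on an aromatic carbon; the chloro group and the rest of the shared core stay as they are. Within the data shown here, no pair of measured compounds differs in this single place, so there is no directly comparable step to lean on. The closest guide is compound 1, which carries a carboxy group in the same spot and gives 7.8 nM in this assay, a number within the scatter of compound 2.

On that basis no step beyond the scatter is expected from compound 2 to compound 4, with perhaps a slight drift towards a lower number, corresponding to a 1.6-fold lower number from compound 2 to compound 4 (0.19 log units; within the scatter). The estimate for compound 4 is 9 nM, with a range from 3 nM to 30 nM.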

Compound 4, half-maximal effective concentration: 7500 nM
The estimate for compound 4 lay 830-fold (2.92 log units) below the measured number, and the stated range ends below it.
By their numbers in this assay, from the lowest: compounds 1 and 2 (each within the scatter of the next); then compound 3; then compound 4.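

With chloro on the ring, the carboxy group cannot stand in for the ((trifluoromethyl)carbonyl)amino group in this assay: the swap gives a 540-fold higher number from compound 2 to compound 4 (2.73 log units; beyond the scatter), a loss far larger than the earlier compounds gave any reason to expect. The second change shows that this position cannot be judged on its own, since with carboxy kept in place, chloro in place of fluoro on the same ring gives a 960-fold higher number from compound 1 to compound 4 (2.98 log units; beyond the scatter), so the same carboxy group is tolerated with fluoro and not with chloro. The compounds shown offer no measurement that accounts for so large a shift from such small changes.

Among these compounds, still open is whether the ((trifluoromethyl)carbonyl)amino group is as sensitive to the halogen as carboxy is, since no compound here pairs it with fluoro. It is also unclear how a carboxy compound would respond to a bromo or methyl group in place of the halogen, or whether a tetrazole or an acetylamino group at the carboxy position would follow carboxy or ((trifluoromethyl)carbonyl)amino.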